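Fluoro on the benzylic ring of compound 1

The source may report more compounds than this note shows. Statements on the series, on what has been measured and on what is new or still open speak of the compounds shown alone.

Measured compounds:
compound 1 `O=C(NCc1ccc(N2CCCCCC2)cc1)Nc1cccc2cnccc12`, 3.3 nM
compound 2 `CC1CN(c2ccc(CNC(=O)Nc3cccc4cnccc34)cc2)CC(C)O1`, 258 nM

In a functional assay for antagonist activity at transient receptor potential cation channel subfamily V member 1 (Homo sapiens), read by calcium flux (a lower number here means a stronger inhibitor, a higher number a weaker inhibitor), compound 1 gives 3.3 nM, the lowest of the two numbers; the nearest measured compound is compound 2, which gives 258 nM. Among the compounds with values here, the only step recorded so far is a 78-fold higher number from compound 1 to compound 2 (1.89 log units; beyond the scatter), a change of the saturated ring on the aromatic carbon. Compound 3 `O=C(NCc1ccc(N2CCCCCC2)c(F)c1)Nc1cccc2cnccc12` differs from compound 1 by fluoro in place of hydrogen on an aromatic carbon. Within the data shown here, no measured step bears on this change: the step from compound 1 to compound 2 swaps a ring rather than adding a single atom to the aromatic ring, and it says nothing about a fluoro substituent. With no relevant comparison, the estimated step of a 1.5-fold higher number from compound 1 to compound 3 (0.18 log units; within the scatter) is expected to be small, within or close to the usual scatter. For compound 3 the expected value in this assay is 5 nM, with a range from 1.5 nM to 20 nM.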

Compound 3, half-maximal inhibitory concentration: 2.8 nM
Compound 3: middle estimate off by 1.8-fold (0.25 log units), on the high side; the range from low to high includes it.
By their numbers in this assay, from the lowest: compounds 3 and 1 (each within the scatter of the next); then compound 2.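

In this assay the result is a 1.2-fold lower number from compound 1 to compound 3 (0.07 log units; within the scatter), so fluoro on the aromatic carbon ortho to an azepan-1-yl group leaves the number where it was, within the scatter. Within the data shown here, the earlier step showed only how much the number depends on the saturated ring, whereas this one is the first reading on the aromatic ring itself, and it shows that this carbon can carry fluoro in place of hydrogen while the low nanomolar value holds. No measured evidence is available to explain this result.

The compounds shown leave open whether a larger group at this carbon, such as chloro, methoxy or trifluoromethyl, would hold the value equally well. They also leave open whether fluoro would have the same small effect alongside the 2,6-dimethylmorpholin-4-yl group.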